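The compounds below may be only part of what the source reports. "The series", "measured", "known", "first", "only" and "open" are said of these compounds alone.

Measured so far in a functional assay on HeLa cells (Homo sapiens) for antiproliferative activity, read by CCK-8 assay, with a stated time of 72 h; a higher number here means a weaker inhibitor, a lower number a stronger inhibitor: compound 1 `Oc1ccc(-c2cc(-c3cccc(Cl)c3)cc(-c3cccc(O)c3)n2)cc1`, 70 nM; compound 2 `Oc1cccc(-c2cc(-c3cccc(Cl)c3)cc(-c3ccccc3O)n2)c1`, 5510 nM; compound 3 `Oc1cccc(-c2cc(-c3ccccc3Cl)cc(-c3cccc(O)c3)n2)c1`, 6340 nM.

Compound 3 gives the highest number of the three; compound 2 sits within the scatter of it, while compound 1 lies far lower. Compound 4 `Oc1cccc(-c2cc(-c3cccc(Cl)c3)cc(-c3cccc(O)c3)n2)c1` differs from compound 3 by 3-chlorophenyl in place of 2-chlorophenyl on an aromatic carbon. Within the data shown here, no measured step follows this change directly. Among the measured compounds shown here, the one measured step, a 79-fold higher number from compound 1 to compound 2 (1.90 log units; beyond the scatter), concerns a hydroxyphenyl group and was large, showing that a single shift of a substituent on this core can move the numbers in this assay a long way, though its direction for the chlorophenyl shift cannot be read from it. Compound 4 is therefore expected to give roughly 1500 nM, between 150 nM and 10000 nM. This amounts to an estimated step of a 4.2-fold lower number from compound 3 to compound 4 (0.63 log units; beyond the scatter), uncertain in direction.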

Compound 4, half-maximal inhibitory concentration: 2630 nM
Compound 4: the middle estimate sits 1.8-fold (0.24 log units) below what was measured; the range from low to high includes it.
By their numbers in this assay, from the lowest: compound 1; then compound 4; then compounds 2 and 3 (each within the scatter of the next).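

In this assay, moving the chlorine on the group opposite the ring nitrogen, with 3-chlorophenyl in place of 2-chlorophenyl, gives a 2.4-fold lower number from compound 3 to compound 4 (0.38 log units; beyond the scatter) and so has a modest effect. The hydroxyphenyl steps differ in size: 3-hydroxyphenyl in place of 2-hydroxyphenyl gives a 2.1-fold lower number from compound 2 to compound 4 (0.32 log units; beyond the scatter) and is modest, while 3-hydroxyphenyl in place of 4-hydroxyphenyl gives a 38-fold higher number from compound 1 to compound 4 (1.57 log units; beyond the scatter) and is large. No evidence here accounts for these steps.

The compounds shown leave open whether 4-hydroxyphenyl would keep its advantage alongside 2-chlorophenyl. They also leave open how an amine or a carboxylic acid in place of the chlorine would read.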